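Fluorine on the Phenyl Ring of Compound 1

The compounds below may be only part of what the source reports. "The series", "measured", "known", "first", "only" and "open" are said of these compounds alone.

Measured compounds:
compound 1 `Cn1c(NCc2ccccc2)c(C#N)c2c(N)ncnc21`, 423 nM
compound 2 `C[C@@H]1CCCN1c1c(C(N)=O)c2c(N)ncnc2n1C`, 77 nM

In an assay on isolated protein for binding affinity to Leucine-rich repeat serine/threonine-protein kinase 2 (Homo sapiens), read by TR-FRET and LanthaScreen, with a stated time of 2 h (a higher number here means a weaker inhibitor, a lower number a stronger inhibitor), compound 1 gives 423 nM, the higher of the two numbers recorded. Compound 2 gives 77 nM, and the gap between these two values lies beyond the scatter. Compound 3 `Cn1c(NCc2ccccc2F)c(C#N)c2c(N)ncnc21` differs from compound 1 by fluoro in place of hydrogen on an aromatic carbon. Within the data shown here, no pair of measured compounds shows a change of this kind, so the expectation rests on compound 1 alone. The change is expected to move the number by no more than the scatter; the estimated step is a 1.2-fold lower number from compound 1 to compound 3 (0.08 log units; within the scatter). Compound 3 is therefore expected to give 350 nM, in the range 150 nM to 900 nM.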

Compound 3, inhibition constant: 145 nM
Compound 3: middle estimate off by 2.4-fold (0.38 log units), on the high side; measured number below the stated range.
By their numbers in this assay, from the lowest: compounds 2 and 3 (each within the scatter of the next); then compound 1.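

In this assay, the change from phenyl to 2-fluorophenyl gives a 2.9-fold lower number from compound 1 to compound 3 (0.46 log units; beyond the scatter). This shows that the ring carbon ortho to a large group responds to fluoro in place of hydrogen, which compound 1 alone could not show, although the step is modest. Nothing measured here accounts for the step. On these data alone, it remains open whether chloro, methyl or methoxy on this carbon would move the number in the same direction. Also open, as far as these compounds go, is whether fluoro on the other carbons of the ring would do so.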